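Trifluoromethyl in place of methyl in compound 2

This account rests on a few compounds, and the source may have more. Where it says the series, first, only, none or still open, it means among the compounds named here.

Within the data shown here, in a functional assay on MCF7 cells (Homo sapiens) for antiproliferative activity, read by MTT assay, with a stated time of 72 h (on this read-out lower numbers stand for stronger inhibition and higher numbers for weaker inhibition), compound 2 `Cc1ccccc1OS(=O)(=O)C1CC2OC1C(c1ccc(/C=C/c3cc(O)cc(O)c3)cc1)=C2c1ccc(O)cc1` gives 55800 nM, the higher of the two numbers measured so far, and compound 1 `O=S(=O)(Oc1ccc(F)cc1)C1CC2OC1C(c1ccc(/C=C/c3cc(O)cc(O)c3)cc1)=C2c1ccc(O)cc1` gives 13100 nM. Compound 3 `O=S(=O)(Oc1ccccc1C(F)(F)F)C1CC2OC1C(c1ccc(/C=C/c3cc(O)cc(O)c3)cc1)=C2c1ccc(O)cc1` differs from compound 2 in one group: trifluoromethyl in place of methyl on an aromatic carbon. It carries trifluoromethyl in place of methyl on an aromatic carbon, ortho to a large group. Among the measured compounds shown here, only one measured step bears on this change, a 4.3-fold higher number from compound 1 to compound 2 (0.63 log units; beyond the scatter), a modest step beyond the scatter with 2-methylphenyl in place of 4-fluorophenyl on an oxygen. That step never exchanges methyl for trifluoromethyl, so it offers only a rough guide to size and little guide to direction. A smaller step is expected, leaning towards a lower number and perhaps not exceeding the scatter. The expected change is a 1.9-fold lower number from compound 2 to compound 3 (0.27 log units; within the scatter). In this assay, compound 3 is estimated at 30000 nM, with an expected range of 10000 nM to 90000 nM.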

Compound 3, half-maximal inhibitory concentration: 18300 nM
Compound 3: the middle estimate sits 1.6-fold (0.21 log units) above what was measured; measured number inside the range.
By their numbers in this assay, from the lowest: compounds 1 and 3 (each within the scatter of the next); then compound 2.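

In this assay, among these compounds, the aromatic carbon ortho to a large group proves sensitive to what it carries: trifluoromethyl in place of methyl gives a 3.0-fold lower number from compound 2 to compound 3 (0.48 log units; beyond the scatter), the first step that changes this group alone. Set against the 4-fluorophenyl group, 2-(trifluoromethyl)phenyl gives a 1.4-fold higher number from compound 1 to compound 3 (0.15 log units; within the scatter), which lies within the scatter, so compound 1 and compound 3 cannot be told apart and only the 2-methylphenyl group of compound 2 stands out among the three. Nothing available accounts for this difference between methyl and trifluoromethyl.

As far as these compounds go, whether a chlorine atom, a methoxy group or an amine on the same carbon would read like methyl or like trifluoromethyl remains open. So does whether trifluoromethyl elsewhere on the six-membered aromatic ring would give a similar number.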